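Branching the Ester Chain: From Propyl to Isobutyl

The source may hold more compounds than are shown below. What is called first, only, known or untested is meant among the compounds shown, and "the series" means these compounds.

Compound 1 `CCOc1cc(NC(=O)C2(NC(=O)c3ccc4c(C5CCCC5)c(-c5ncc(Cl)cn5)n(C)c4c3)CCC2)ccc1/C=C/C(=O)OC(=O)C[C@H](O)C(=O)O` gives 5.57 h in an ADME assay (liver) for pharmacokinetics, with Liver microsome (Homo sapiens) as the target, using microsomes; a higher number here means that the compound lasts longer, a lower number that the compound disappears faster. Compound 2 `CCCOC(=O)/C=C/c1ccc(NC(=O)C2(NC(=O)c3ccc4c(C5CCCC5)c(-c5ncc(Cl)cn5)n(C)c4c3)CCC2)cc1OCC` reaches only a limit of the assay in this assay, > 5 h, so no number is known for it. The step that the limit leaves unreadable from compound 1 to compound 2 therefore cannot be read, since the limit of > 5 h in this assay, at which 1 of the 2 values shown sits, marks where compound 2 sits. Compound 3 `CCOc1cc(NC(=O)C2(NC(=O)c3ccc4c(C5CCCC5)c(-c5ncc(Cl)cn5)n(C)c4c3)CCC2)ccc1/C=C/C(=O)OCC(C)C` differs from compound 2 by methyl in place of hydrogen on a saturated chain carbon bound to two saturated chain carbons. Within the data shown here, no measured step touches this kind of change, and the only measured step, the one from compound 1 to compound 2, is itself unreadable in size. Compound 2 stands at a limit, so the expectation for compound 3 rests on that position alone, and a step that the limit leaves unreadable from compound 2 to compound 3 is expected, none beyond the scatter. Compound 3 is estimated at 6 h, with a range from 3 h to 12 h, and it may again be reported only as a limit.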

Compound 3, half-life: > 5 h
Compound 3 was reported as a limit (the forecaster's own chance of this, stated with the estimate: 60%); the middle value does not contradict the limit.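

In this assay, no step among compound 1, compound 2 and compound 3 can be read, as compound 2 and compound 3 both rest at a limit of the assay: the limit of > 5 h in this assay, at which 2 of the 3 values shown sit.

The compounds shown leave open how long compound 2 and compound 3 actually last, and whether the added methyl changes the half-life at all.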